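The source may report more compounds than this note shows. Statements on the series, on what has been measured and on what is new or still open speak of the compounds shown alone.

Three measured compounds share one core and differ only in the aryl group on the saturated ring carbon. Compound 1 `Cc1cc(O)c(C2=NN(c3ccc(S(N)(=O)=O)cc3)C(c3ccccc3O)C2)cc1Cl` gives 3640 nM in a functional assay on HCT-15 cells (Homo sapiens) for antiproliferative activity, with a stated time of 48 h; a higher number here means a weaker inhibitor of growth, a lower number a stronger inhibitor of growth. Compound 2 `Cc1cc(O)c(C2=NN(c3ccc(S(N)(=O)=O)cc3)C(c3ccccc3Cl)C2)cc1Cl` gives 3690 nM in this assay, and compound 3 `COc1ccc(C2CC(c3cc(Cl)c(C)cc3O)=NN2c2ccc(S(N)(=O)=O)cc2)cc1OC` gives 3320 nM. Compound 3 holds the lowest of the three numbers, yet a 1.1-fold lower number from compound 1 to compound 3 (0.04 log units; within the scatter) and a 1.1-fold lower number from compound 2 to compound 3 (0.05 log units; within the scatter) both lie within the scatter, as does a 1.0-fold higher number from compound 1 to compound 2 (0.01 log units; within the scatter), so none of the three can be told apart from the others on these numbers.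

Compound 4 `COc1ccc(C2CC(c3cc(Cl)c(C)cc3O)=NN2c2ccc(S(N)(=O)=O)cc2)c(OC)c1OC` differs from compound 3 by methoxy in place of hydrogen on an aromatic carbon. Among the measured compounds shown here, no measured step adds a group to the aryl ring on the saturated carbon. The nearest analogies, a 1.1-fold lower number from compound 1 to compound 3 (0.04 log units; within the scatter) and a 1.1-fold lower number from compound 2 to compound 3 (0.05 log units; within the scatter), exchanged that whole aryl group and still moved the number by less than the scatter. On that basis the step expected in this assay is a 1.0-fold lower number from compound 3 to compound 4 (0.00 log units; within the scatter), that is, no change beyond the scatter in either direction. For compound 4 the estimate in this assay is 3300 nM, with a range from 1700 nM to 6600 nM.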

Compound 4, concentration for 50% growth inhibition: 3280 nM
For compound 4 the middle estimate is 1.0-fold (0.00 log units) above the measured one, within the range that was stated.
By their numbers in this assay, from the lowest: compounds 4, 3, 1 and 2 (each within the scatter of the next).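

In this assay, among the compounds shown here, methoxy in place of hydrogen on an aromatic carbon, ortho to a large group and ortho to a methoxy group, gives a 1.0-fold lower number from compound 3 to compound 4 (0.01 log units; within the scatter); this is the first step here that adds a group to this aryl ring, not one that exchanges the whole aryl group. The 2,3,4-trimethoxyphenyl group also stays level with the other aryl groups on the saturated ring carbon, with a 1.1-fold lower number from compound 2 to compound 4 (0.05 log units; within the scatter) and a 1.1-fold lower number from compound 1 to compound 4 (0.05 log units; within the scatter), so all four aryl groups shown fall within the scatter of one another, and this added methoxy leaves the number as flat as the whole-group exchanges did. Nothing available gives a reason for this flatness.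

The compounds shown leave open whether an amine or a carboxylic acid on this aryl ring, or a plain alkyl chain in place of the whole aryl group, would move the number beyond the scatter in this assay. On these data alone, all four compounds also carry the same shared core, so the effect of any change elsewhere on it remains unknown.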